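The source may hold more compounds than are shown below. What is called first, only, known or untested is meant among the compounds shown, and "the series" means these compounds.

Working notes on the sulfonyl-aryl variation of a shared core. Compound 1 `CC1=NC(c2cn(S(=O)(=O)c3ccc(Cl)cc3)c3ccc(C)cc23)CN1` gives 1900 nM in an assay on isolated protein for inhibition of kallikrein-7 (Homo sapiens), read by fluorescence, with stated times of 10 min and 30 min; on this read-out lower numbers stand for stronger inhibition and higher numbers for weaker inhibition. Compound 2 `CC1=NC(c2cn(S(=O)(=O)c3ccc(F)cc3)c3ccc(C)cc23)CN1` gives 9400 nM in this assay, the step being a 4.9-fold higher number from compound 1 to compound 2 (0.69 log units; beyond the scatter). Compound 3 `CC1=NC(c2cn(S(=O)(=O)c3ccccc3F)c3ccc(C)cc23)CN1` gives 4100 nM in this assay and stands second highest of the three numbers, with a 2.2-fold higher number from compound 1 to compound 3 (0.33 log units; beyond the scatter) and a 2.3-fold lower number from compound 2 to compound 3 (0.36 log units; beyond the scatter). Compound 4 `CC1=NC(c2cn(S(=O)(=O)c3ccccc3C)c3ccc(C)cc23)CN1` differs from compound 3 by methyl in place of fluoro on an aromatic carbon. Within the data shown here, no measured step exchanges fluoro for methyl; the steps that bear on it are the three already given, all modest and all on the phenyl carried by the sulfonyl sulfur, the largest being a 4.9-fold higher number from compound 1 to compound 2 (0.69 log units; beyond the scatter). A step of comparable modest size, most likely toward a lower number, is expected, a 1.6-fold lower number from compound 3 to compound 4 (0.21 log units; within the scatter). Compound 4 is estimated at 2500 nM, within 900 nM to 7000 nM.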

Compound 4, half-maximal inhibitory concentration: 1000 nM
The estimate for compound 4 lay 2.5-fold (0.40 log units) above the measured number, within the range that was stated.
By their numbers in this assay, from the lowest: compounds 4 and 1 (each within the scatter of the next); then compound 3; then compound 2.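

On the sulfonyl sulfur, 2-methylphenyl in place of 2-fluorophenyl gives a 4.1-fold lower number from compound 3 to compound 4 (0.61 log units; beyond the scatter) and shows that, ortho to a large group, the number responds to a change of group and not only to a change of the place of fluoro. The same 2-methylphenyl gives a 9.4-fold lower number from compound 2 to compound 4 (0.97 log units; beyond the scatter) as the widest step in the set, yet a 1.9-fold lower number from compound 1 to compound 4 (0.28 log units; within the scatter) leaves these two compounds unordered. No measurement at hand accounts for these steps.

As far as these compounds go, whether ethyl, methoxy or an amine at this place would carry the number lower stays open.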